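The source may hold more compounds than are shown below. What is called first, only, known or untested is meant among the compounds shown, and "the series" means these compounds.

Compound 2 `CO[C@@H]1OC[C@@]2(C)CCC[C@@]13c1cc(O)c(C(C)C)cc1CC[C@@H]23` gives > 10000 nM in a functional assay on HCT-8 cells (Homo sapiens) for cytotoxicity, read by MTT assay, with a stated time of 24 h (a lower number here means a stronger inhibitor, a higher number a weaker inhibitor), as a limit and not a number. Compound 1 `CC(C)c1cc2c(cc1O)[C@]13CCC[C@](C)(CO[C@H]1O)[C@@H]3CC2` gives > 10000 nM as a limit too. Compound 3 `CO[C@H]1OC[C@@]2(C)CCC[C@@]13c1cc(O)c(C(C)C)cc1CC[C@@H]23` gives > 10000 nM as a limit as well. Compound 4 `CCO[C@@H]1OC[C@@]2(C)CCC[C@@]13c1cc(O)c(C(C)C)cc1CC[C@@H]23` differs from compound 2 by methyl in place of hydrogen on a saturated chain carbon bound to an oxygen on a saturated carbon so that methoxy becomes ethoxy. Bearing on this change are a step that the two limits leave unreadable from compound 1 to compound 2 and a step that the two limits leave unreadable from compound 2 to compound 3 as the measured steps. Neither size can be read because of the limit of > 10000 nM in this assay, at which 3 of the 3 values shown sit, and so no step beyond the scatter is expected in this assay in either direction. The expected size is a step that the limit leaves unreadable from compound 2 to compound 4 as an estimate only. For compound 4 the estimated value is 15000 nM with a range of 7000 nM to 40000 nM and the assay may well report only a limit.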

Compound 4, half-maximal inhibitory concentration: > 10000 nM
Compound 4: only a limit was reported (the forecaster's own chance of this, stated with the estimate: 90%); the middle value does not contradict the limit.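

The steps from compound 1 and from compound 2 to compound 4 cannot be read, because these results are limits and not numbers: the limit of > 10000 nM in this assay, at which 4 of the 4 values shown sit. The compounds shown leave open which change to the shared core, if any, would give a measurable value in this assay.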